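Notes on fluorosulfonylphenyl amides in the series

The compounds below may be only part of what the source reports. "The series", "measured", "known", "first", "only" and "open" are said of these compounds alone.

Measured so far:
compound 1, `CC1(C)N=C(N)N=C(N)N1c1ccc(OCCCC(=O)Nc2cccc(S(=O)(=O)F)c2)c(Cl)c1`, gives 7.17 in an assay on isolated protein for inhibition of Dihydrofolate reductase (Mus musculus); on this read-out lower numbers stand for lower potency and higher numbers for higher potency (the scale is a negative logarithm).
compound 2, `CC1(C)N=C(N)N=C(N)N1c1ccc(SCC(=O)Nc2ccc(S(=O)(=O)F)cc2)c(Cl)c1`, gives 7.42 in this assay.
compound 3, `CC1(C)N=C(N)N=C(N)N1c1ccc(OCCCC(=O)Nc2ccc(S(=O)(=O)F)cc2)c(Cl)c1`, gives 7.15 in this assay.

Among the compounds with values here, the one change that has been measured directly is 3-(fluorosulfonyl)phenyl in place of 4-(fluorosulfonyl)phenyl on an amide-type nitrogen; it made a step of a number 0.02 log units higher from compound 3 to compound 1 (within the scatter). Compound 2 carries a different core from compound 3, and the difference between the two cores is not broken down here; their two values lie within the scatter of each other, and nothing more is read into the pair.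

Compound 4, `CC1(C)N=C(N)N=C(N)N1c1ccc(SCC(=O)Nc2cccc(S(=O)(=O)F)c2)c(Cl)c1`, is not yet measured. It stands to compound 2 as compound 1 stands to compound 3: the change is 3-(fluorosulfonyl)phenyl in place of 4-(fluorosulfonyl)phenyl on an amide-type nitrogen, at the same place as before, so it is the same change made on the other core. Within the data shown here, with only one earlier instance, the expectation rests on that instance alone. The step from compound 2 to compound 4 is expected to be a number 0.02 log units higher from compound 2 to compound 4 (within the scatter), beside the earlier a number 0.02 log units higher from compound 3 to compound 1 (within the scatter). Compound 4 is therefore estimated at 7.44 in this assay, with a range of 7.1 to 7.8.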

Compound 4, logarithm of the reciprocal of the active concentration, log(1/C): 7.66
Beside the measured number, compound 4's estimate is 0.22 log units below it, within the range that was stated.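

In this assay, 3-(fluorosulfonyl)phenyl in place of 4-(fluorosulfonyl)phenyl on an amide-type nitrogen gives a step of a number 0.24 log units higher from compound 2 to compound 4 (within the scatter). Set beside the earlier instance, the change carried to the core of compound 2 does not differ from the same change on the core of compound 3: the same change on two cores in this assay, a number 0.02 log units higher (within the scatter) from compound 3 to compound 1 and a number 0.24 log units higher (within the scatter) from compound 2 to compound 4, 0.22 log units apart, within the scatter of two such steps. Within the data shown here, neither step lies beyond the scatter, which shows only that the change can be carried between these two cores with no measurable shift in the read-out; it does not show that the change has a real effect on either core, and two instances set no rule for any other core.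

The compounds shown leave open whether the amide-type nitrogen accepts a phenyl ring carrying a carboxylic acid or an amine instead of the fluorosulfonyl group. They also leave open what a longer chain in the linker would do on either core.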